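Exchanging the aryl group on a shared core

This account rests on a few compounds, and the source may have more. Where it says the series, first, only, none or still open, it means among the compounds named here.

Of the compounds shown here, two built on the same shared core have been measured in a functional assay on CCRF-CEM cells (Homo sapiens) for inhibition; a higher number here means a weaker inhibitor, a lower number a stronger inhibitor. Compound 1 `Cc1csc(-c2ncnc3c2ncn3C2O[C@H](CO)[C@@H](O)[C@H]2O)c1` carries a 4-methylthiophen-2-yl group, and in this assay compound 1 gives 2900 nM. Compound 2 `OC[C@H]1OC(n2cnc3c(-c4ccc(F)cc4)ncnc32)[C@H](O)[C@@H]1O` carries 4-fluorophenyl in its place, and in this assay compound 2 gives 700 nM. That single exchange produced a 4.1-fold lower number from compound 1 to compound 2 (0.62 log units; beyond the scatter). Going by the values given here, compound 2 therefore stands lowest of the two numbers, with compound 1 as its only neighbour.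

Compound 3 `Cn1cccc1-c1ncnc2c1ncn2C1O[C@H](CO)[C@@H](O)[C@H]1O` is the next variation: 1-methyl-1H-pyrrol-2-yl in place of 4-fluorophenyl on an aromatic carbon. Among the compounds with values here, only one measured step bears on this change, namely a 4.1-fold lower number from compound 1 to compound 2 (0.62 log units; beyond the scatter), in which a five-membered aromatic ring gave way to a six-membered one and the number fell. Compound 3 brings back a five-membered aromatic ring, though one with nitrogen rather than sulfur, so the number is expected to move back upward by a modest amount, a 2.1-fold higher number from compound 2 to compound 3 (0.33 log units; beyond the scatter). Compound 3 is thus expected to give 1500 nM in this assay, within a range from 500 nM to 4500 nM.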

Compound 3, half-maximal inhibitory concentration: 2000 nM
For compound 3 the middle estimate is 1.3-fold (0.12 log units) below the measured one; measured number inside the range.
By their numbers in this assay, from the lowest: compound 2; then compounds 3 and 1 (each within the scatter of the next).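

In this assay, putting 1-methyl-1H-pyrrol-2-yl in place of 4-fluorophenyl gives a 2.9-fold higher number from compound 2 to compound 3 (0.46 log units; beyond the scatter), so a second exchange at this aromatic carbon also moves the number beyond the scatter, and the compound with the six-membered aromatic ring stands apart from both compounds with a five-membered one. Exchanging 4-methylthiophen-2-yl for 1-methyl-1H-pyrrol-2-yl gives a 1.5-fold lower number from compound 1 to compound 3 (0.16 log units; within the scatter), so the two five-membered aromatic rings, one with sulfur and one with nitrogen, cannot be told apart in this assay. No accompanying measurement offers an explanation for these differences.

The three compounds leave open whether ring size, the fluorine or some other difference sets compound 2 apart, as the ring and its substituent change together in each exchange. On these data alone, how the number would respond to an amine, a carboxylic acid or a longer chain on the aromatic ring at this position also remains open.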